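Bicyclic amine ethers: aryloxy variation, compound 3

A few compounds are considered here, and "the series" means these few. Any claim that something is new, unique, unknown or untested is made for them only; others in the source may bear on it.

Measured so far:
compound 1 `CC(C)c1ccc(OCC2[C@H]3CN(Cc4nc5ccccc5n4C)C[C@@H]23)cc1`, 26 nM
compound 2 `Cn1c(CN2C[C@@H]3C(COc4ccc(Cl)cc4F)[C@@H]3C2)nc2ccccc21`, 8 nM

Both were measured in an in vitro assay on HEK293 cells with metabotropic glutamate receptor 2 (Rattus norvegicus) as the target, read by FLIPR, in the presence of a further agent that is not named here; on this read-out lower numbers stand for an effect already at smaller amounts and higher numbers for an effect only at larger amounts of compound. Within the data shown here, the only step in hand is the change of the aryl group on the ether oxygen: a 3.3-fold lower number from compound 1 to compound 2 (0.51 log units; beyond the scatter). On these two numbers compound 2 stands at the lower end, with compound 1 the nearest neighbour and the gap beyond the scatter.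

Compound 3 `Cn1c(CN2C[C@@H]3C(COc4ccc(Cl)nc4)[C@@H]3C2)nc2ccccc21` has not been measured. It differs from compound 2 in one place: 6-chloropyridin-3-yl in place of 4-chloro-2-fluorophenyl on an oxygen on a saturated carbon. Among the measured compounds shown here, no measured step bears directly on this exchange; the one step on record changes the aryl group at the same oxygen, and it shows that the group there moves the number by a modest amount. An exchange of this size is therefore expected to give at most a modest step in this assay, in either direction, possibly none beyond the scatter. The estimate for compound 3 is 15 nM, range 4 nM to 60 nM, which corresponds to an expected step of a 1.9-fold higher number from compound 2 to compound 3 (0.27 log units; within the scatter).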

Compound 3, half-maximal effective concentration: 511 nM
Beside the measured number, compound 3's estimate is 34-fold (1.53 log units) below it; measured number above the stated range.
By their numbers in this assay, from the lowest: compound 2; then compound 1; then compound 3.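

In this assay the aryl group on the oxygen on a saturated carbon turns out to have far more reach than the earlier 3.3-fold lower number from compound 1 to compound 2 (0.51 log units; beyond the scatter) suggested: 6-chloropyridin-3-yl in place of 4-chloro-2-fluorophenyl gives a 64-fold higher number from compound 2 to compound 3 (1.81 log units; beyond the scatter), a large step. The same group also loses to 4-isopropylphenyl, with a 20-fold higher number from compound 1 to compound 3 (1.29 log units; beyond the scatter), so compound 3 has the highest number of the three, beyond the scatter against both others. Chlorine is present in both groups of the 2-to-3 exchange, so keeping it does not by itself hold the number low, and an aryl group at this oxygen is not interchangeable with any other of similar size. Nothing measured here accounts for the size of this step.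

The exchange removes fluorine and brings in a ring nitrogen at once, so the compounds shown do not tell which of the two carries the step, and a 4-chlorophenyl group at the same oxygen would separate them. Also open, as far as these compounds go, is whether another pyridine substituent, such as methoxy or an amine in place of chlorine, behaves like the 6-chloropyridin-3-yl group.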